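This account rests on a few compounds, and the source may have more. Where it says the series, first, only, none or still open, it means among the compounds named here.

Compound 1 `Cc1cc(CNC(C)(C)C)c(O)c(Nc2nc3ccccc3[nH]2)c1`: 33300 nM
Compound 2 `Cc1cc(CN)c(O)c(Nc2nc3ccccc3n2Cc2ccc(C(F)(F)F)cc2)c1`: 47600 nM

In an ADME assay on CHO cells (Cricetulus griseus) for inhibition, read by MTT assay (a higher number here means a weaker inhibitor, a lower number a stronger inhibitor), compound 2 gives 47600 nM, and compound 1 gives 33300 nM. These two values lie within the usual scatter of each other, so compound 2 cannot be separated from compound 1 on these numbers. Compound 3 `Cc1cc(CNC(C)(C)C)c(O)c(Nc2nc3ccccc3n2Cc2ccc(C(F)(F)F)cc2)c1` differs from compound 2 by one change, tert-butyl in place of hydrogen on an amine nitrogen. Among the measured compounds shown here, no measured pair shows this change, so only a modest move towards a lower number is expected, a 2.4-fold lower number from compound 2 to compound 3 (0.38 log units; beyond the scatter). For compound 3 the estimated value is 20000 nM, with an expected range of 6000 nM to 50000 nM.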

Compound 3, half-maximal inhibitory concentration: 30000 nM
Estimate against measurement, compound 3: 1.5-fold (0.18 log units) below, within the range that was stated.
By their numbers in this assay, from the lowest: compounds 3, 1 and 2 (each within the scatter of the next).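

In this assay, tert-butyl in place of hydrogen on the amine nitrogen gives a 1.6-fold lower number from compound 2 to compound 3 (0.20 log units; within the scatter), so this large group leaves no readable mark at this position. Likewise, 4-(trifluoromethyl)benzyl in place of hydrogen on the aromatic nitrogen gives a 1.1-fold lower number from compound 1 to compound 3 (0.05 log units; within the scatter), so with tert-butyl present, that change cannot be read either. As far as these compounds go, whether a methyl group on the amine nitrogen, or a carboxylic acid in place of trifluoromethyl on the benzyl group, would move the number beyond the scatter stays open. No supporting measurement bears on these results.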